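A few compounds are considered here, and "the series" means these few. Any claim that something is new, unique, unknown or untested is made for them only; others in the source may bear on it.

Three compounds of the series have readings in an ADME assay on CHO cells (Cricetulus griseus) for cytotoxicity, read by MTT assay; on this read-out lower numbers stand for stronger inhibition and higher numbers for weaker inhibition. Compound 1 `Cc1cc(C)n(-c2nc(-c3ccccc3)c(C)c(=O)[nH]2)n1` gives 25000 nM, and compound 2 `Cn1ccnc1-c1nc(-c2ccccc2)cc(=O)[nH]1` gives 4000 nM. Compound 3 `Cc1cc(-c2ccccc2)n(-c2nc(C(F)(F)F)cc(=O)[nH]2)n1` gives only a limit of the assay, > 50000 nM. That is the limit of > 50000 nM in this assay, at which 1 of the 3 values shown sits, so the place of compound 3 among the three is fixed no closer than the limit itself. Compound 4 `Cc1cc(Nc2ccc(F)cc2)n(-c2nc(C(F)(F)F)cc(=O)[nH]2)n1` is not yet measured and carries (4-fluorophenyl)amino in place of phenyl on an aromatic carbon. Within the data shown here, no step between measured compounds is at hand, so the size of this change has no precedent. The expectation is that compound 4 stays near the limit of compound 3, with a step of a number no higher from compound 3 to compound 4 (the limit leaves the size open), none beyond the scatter. In this assay compound 4 is estimated at 50000 nM, in the range 20000 nM to 120000 nM.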

Compound 4, half-maximal inhibitory concentration: 20000 nM
The estimate for compound 4 lay 2.5-fold (0.40 log units) above the measured number; the measured number falls inside the stated range.
By their numbers in this assay, from the lowest: compound 2; then compounds 4 and 1 (each within the scatter of the next). At a limit, above all of these: compound 3.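

In this assay, (4-fluorophenyl)amino in place of phenyl on an aromatic carbon gives an at least 2.5-fold lower number from compound 3 to compound 4 (0.39 log units; beyond the scatter), the first one-place change readable in the series. This position on the five-membered ring therefore affects the read-out, and compound 4 gives a measured number, 20000 nM. Compound 3 stands at a limit, so this step is only a bound: the limit of > 50000 nM in this assay, at which 1 of the 4 values shown sits.

The compounds shown do not separate the contribution of the amino nitrogen from that of the fluorine. Phenylamino, or a small amine such as morpholine, on this carbon remains open, as does the true size of the step.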